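A few compounds are considered here, and "the series" means these few. Any claim that something is new, unique, unknown or untested is made for them only; others in the source may bear on it.

Working notes on the series. Compound 1 `Nc1nc(N)c2c(-c3cc4ccccc4o3)cn([C@@H]3O[C@H](CO)[C@@H](O)[C@H]3O)c2n1` is measured in a functional assay on HepG2 cells (Homo sapiens) for antiproliferative activity, read by XTT assay, with a stated time of 72 h; a lower number here means a stronger inhibitor, a higher number a weaker inhibitor. In this assay compound 1 gives > 20000 nM, which is a limit of the assay and not a number. Compound 2 `CNc1ncnc2c1c(-c1ccccc1)cn2[C@@H]1O[C@H](CO)[C@@H](O)[C@H]1O` gives > 20000 nM in this assay, again a limit. Compound 3 `Cc1nc(N)c2c(-c3cc4ccccc4o3)cn([C@@H]3O[C@H](CO)[C@@H](O)[C@H]3O)c2n1` gives > 20000 nM in this assay, also a limit. For the measured compounds named here, the one measured step, a step that the two limits leave unreadable from compound 1 to compound 3, is therefore unreadable, since the limit of > 20000 nM in this assay, at which 3 of the 3 values shown sit, covers every value shown. Compound 4 `Cc1nc(N)c2c(I)cn([C@@H]3O[C@H](CO)[C@@H](O)[C@H]3O)c2n1` is not yet measured; it differs from compound 3 by iodo in place of 1-benzofuran-2-yl on an aromatic carbon. Going by the values given here, no measured step bears on this change and no numbered value anchors the series. Compound 4 is expected to sit at or near the limit, an estimated 20000 nM (range 5000 nM to 60000 nM). The expected step is a number no higher from compound 3 to compound 4 (the limit leaves the size open), with a further limit the likeliest outcome.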

Compound 4, half-maximal inhibitory concentration: 6310 nM
The estimate for compound 4 lay 3.2-fold (0.50 log units) above the measured number, and the stated range covers the measured number.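

In this assay, the position two ring bonds from the ring nitrogen responds to the group it carries: iodo in place of 1-benzofuran-2-yl gives an at least 3.1-fold lower number from compound 3 to compound 4 (0.50 log units; beyond the scatter). Compound 4 is the only compound shown with a number rather than a limit, so this change gives the series its first readable step. The step from compound 1 to compound 3 cannot be read, and the earlier compounds gave no view of this position: the limit of > 20000 nM in this assay, at which 3 of the 4 values shown sit.

As far as these compounds go, whether iodo itself matters or simply the loss of 1-benzofuran-2-yl stays open, as does what chloro or a small amine would give here. From the compounds shown here alone, whether amino in place of methyl on the core would change the number of compound 4 also remains open.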